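A few compounds are considered here, and "the series" means these few. Any claim that something is new, unique, unknown or untested is made for them only; others in the source may bear on it.

Measured compounds:
compound 1, `Nc1nc(Cl)c2ncn(Cc3ccccc3CCl)c2n1`: 53700 nM
compound 2, `ClCc1ccccc1Cn1cnc2nc(Cl)nc(Cl)c21`: 5750 nM

The two compounds were measured in a functional assay on A549 cells (Homo sapiens) for cytotoxicity, read by sulforhodamine B assay, with a stated time of 48 h; a lower number here means a stronger inhibitor of growth, a higher number a weaker inhibitor of growth. Compound 1 gives 53700 nM, the highest of the two numbers. Within the data shown here, compound 2 gives 5750 nM, a lower number; the gap between the two lies beyond the scatter of this kind of measurement, but no direct step between them is worked out here, so only their two values speak.

The piece follows a single change from compound 1 to compound 3, `ClCc1ccccc1Cn1cnc2c(Cl)ncnc21`, which has not yet been measured in this assay. The change is hydrogen in place of amino on an aromatic carbon.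

Among the measured compounds shown here, no step between measured compounds is available, so the expected size must rest on the two values alone. For the measured compounds named here, since compound 2, the one neighbour with a different group on the shared core, gives 5750 nM, a lower number than compound 1, compound 3 is expected to move in the same direction, downward, by a moderate amount that lies beyond the scatter. The step from compound 1 to compound 3 is estimated as a 3.6-fold lower number from compound 1 to compound 3 (0.55 log units; beyond the scatter). Compound 3 is therefore expected to give about 15000 nM in this assay, with a range from 4000 nM to 50000 nM.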

Compound 3, concentration for total growth inhibition: 25700 nM
The estimate for compound 3 lay 1.7-fold (0.23 log units) below the measured number; low and high end bracket the measured number.
By their numbers in this assay, from the lowest: compound 2; then compound 3; then compound 1.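

In this assay, the amino group on the aromatic carbon between two ring nitrogen atoms can give way to hydrogen with a modest gain: the step is a 2.1-fold lower number from compound 1 to compound 3 (0.32 log units; beyond the scatter). Among these compounds, this is the first direct reading at this position, and it shows that the growth inhibition of compound 1 does not depend on the amino group, since the number falls once that group has gone. Together with compound 2, which carries chloro on the same carbon and gives 5750 nM, while compound 3 gives 25700 nM, the three compounds rank chloro, then hydrogen, then amino, from the lowest number to the highest. No measured evidence accounts for this order or for the size of the step.

The compounds shown leave open whether a methyl, a methoxy or a dimethylamino group on this carbon would fall within that order or outside it. They also leave open whether the same order would hold if the chloromethyl group of the shared structure were replaced by a hydroxymethyl group.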